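Hydroxy in place of methyl on the aromatic amide ring

A few compounds are considered here, and "the series" means these few. Any claim that something is new, unique, unknown or untested is made for them only; others in the source may bear on it.

In a functional assay on OVCAR-5 cells (Homo sapiens) for inhibition, read by CCK-8 assay, with a stated time of 72 h, tested at 10 uM (on this read-out higher numbers stand for more inhibition of growth at the one concentration tested and lower numbers for less inhibition of growth), compound 3 `Cc1ccc(NC(=O)C2(C(=O)Nc3ccc(Nc4ncc5cc(C(=O)N(C)C)n(C6CCCC6)c5n4)cc3)CC2)cc1` gives 80.6%. That value lies within the scatter of compound 1 `CN(C)C(=O)c1cc2cnc(Nc3ccc(NC(=O)C4(C(=O)Nc5ccc(F)cc5)CC4)cc3)nc2n1C1CCCC1`, at 79.7%, and of compound 2 `CN(C)C(=O)c1cc2cnc(Nc3ccc(NC(=O)C4(C(=O)Nc5cccc(O)c5)CC4)cc3)nc2n1C1CCCC1`, at 86%.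

Compound 4 `CN(C)C(=O)c1cc2cnc(Nc3ccc(NC(=O)C4(C(=O)Nc5ccc(O)cc5)CC4)cc3)nc2n1C1CCCC1` has hydroxy in place of methyl on an aromatic carbon, para to a large group, which turns 4-methylphenyl into 4-hydroxyphenyl: hydroxy in place of methyl on an aromatic carbon.

Within the data shown here, three measured steps bear on this change, all on the aromatic group of the same amide. Methyl in place of fluoro gave a number 0.9 percentage points higher from compound 1 to compound 3 (within the scatter). The 3-hydroxyphenyl group in place of 4-fluorophenyl gave a number 6.3 percentage points higher from compound 1 to compound 2 (within the scatter), and 4-methylphenyl in place of 3-hydroxyphenyl gave a number 5.4 percentage points lower from compound 2 to compound 3 (within the scatter). Among the measured compounds shown here, none of these leaves the scatter, and compound 2, the only measured compound carrying hydroxy, gives 86%. No step beyond the scatter is therefore expected in this assay, and the expected step is a number 2.4 percentage points higher from compound 3 to compound 4 (within the scatter). The estimate for compound 4 is 83%, with an expected range from 73% to 92%.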

Compound 4, percent growth inhibition at one concentration: 90.9%
Compound 4: middle estimate off by 7.9 percentage points, on the low side; measured number inside the range.
By their numbers in this assay, from the lowest: compounds 1, 3, 2 and 4 (each within the scatter of the next, the first and the last beyond it).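

Hydroxy in place of methyl gives a number 10.3 percentage points higher from compound 3 to compound 4 (beyond the scatter) in this assay and hydroxy in place of fluoro gives a number 11.2 percentage points higher from compound 1 to compound 4 (beyond the scatter) on the same aromatic carbon, the first steps on this aromatic amide group to leave the scatter. By contrast, 4-hydroxyphenyl in place of 3-hydroxyphenyl gives a number 4.9 percentage points higher from compound 2 to compound 4 (within the scatter) and so does not separate the two hydroxyphenyl compounds on this read-out. Nothing available explains why hydroxy differs from methyl or fluoro at this position.

From the compounds shown here alone, whether the step is specific to hydroxy stays open: an amino group, a methoxy group or a carboxylic acid on the same aromatic carbon would test that. The compounds shown also leave open whether this order holds at other concentrations or in other cell lines.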